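Amide to urea on a shared pyrazole-bearing core: toxicity expected

This account rests on a few compounds, and the source may have more. Where it says the series, first, only, none or still open, it means among the compounds named here.

The account follows compound 1 `COc1cc(-c2nn(-c3cccc(NC(=O)c4ccc(Cl)c(C(F)(F)F)c4)c3)cc2-c2ccncc2)ccc1Cl` and its urea relative compound 4 `COc1cc(-c2nn(-c3cccc(NC(=O)Nc4ccc(Cl)c(Cl)c4)c3)cc2-c2ccncc2)ccc1Cl`, read out in a functional assay on M14 cells (Homo sapiens) for inhibition, read by sulforhodamine B assay, with a stated time of 48 h; on this read-out higher numbers stand for lower toxicity in this test and lower numbers for higher toxicity in this test. In this assay compound 1 gives > 32500 nM, which is a limit of the assay rather than a number. Compound 1 therefore stands only at the edge of what the assay reports, a position it shares with one other value shown: the limit of > 32500 nM in this assay, at which 2 of the 3 values shown sit.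

Two ureas on a closely related core frame the question. Compound 2 `O=C(Nc1cccc(-n2cc(-c3ccncc3)c(-c3ccc(Cl)c(O)c3)n2)c1)Nc1cc(C(F)(F)F)cc(C(F)(F)F)c1` gives 6060 nM in this assay. Compound 3 `O=C(Nc1cccc(-n2cc(-c3ccncc3)c(-c3ccc(Cl)c(O)c3)n2)c1)Nc1ccc(Cl)c(C(F)(F)F)c1` gives > 32500 nM in this assay, again a limit and not a number. Going by the values given here, no two of the measured compounds differ in a single place, so no measured step is available.

Compound 4 differs from compound 1 as follows ((3,4-dichlorophenyl)amino in place of 4-chloro-3-(trifluoromethyl)phenyl on a carbonyl carbon). On the numbers shown, the expected step of an at least 1.1-fold lower number from compound 1 to compound 4 (0.06 log units; that floor lies within the scatter) is small, and the estimate for compound 4 sits near the limit, because compound 1 gives > 32500 nM and compound 3, the urea carrying the 4-chloro-3-(trifluoromethyl)phenyl group, gives > 32500 nM. Compound 4 is therefore estimated at 28000 nM in this assay, within a range from 7000 nM to 60000 nM, with a real chance that only a limit is reported.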

Compound 4, concentration lethal to 50% of the cells: 41200 nM
Compound 4: middle estimate off by 1.5-fold (0.17 log units), on the low side, within the range that was stated.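

No step can be read from compound 1 to compound 4, because compound 1 is held at a limit and not a number: the limit of > 32500 nM in this assay, at which 2 of the 4 values shown sit.

The compounds shown leave open how large the effect on this assay is, and in which direction it runs, when (3,4-dichlorophenyl)amino takes the place of 4-chloro-3-(trifluoromethyl)phenyl on the carbonyl carbon.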